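A nitrile on the aromatic ring of compound 1

A few compounds are considered here, and "the series" means these few. Any claim that something is new, unique, unknown or untested is made for them only; others in the source may bear on it.

Measured compounds:
Compound 1 `c1cncc(N2CC[C@H]3CN[C@H]3C2)c1`: in a functional assay on HEK293 cells for agonist activity at Neuronal acetylcholine receptor; alpha3/beta4 (Homo sapiens), read by FLIPR (a higher number here means that more compound is needed for the effect, a lower number that less compound is needed), compound 1 gives 48 nM.
Compound 2 `Clc1ccc(N2CC[C@H]3CN[C@H]3C2)cn1`: in this assay compound 2 gives 29 nM.

Of the two numbers in this assay, compound 1 has the highest; its nearest neighbour is compound 2, with a 1.7-fold lower number from compound 1 to compound 2 (0.22 log units; within the scatter). Compound 3 `N#Cc1cncc(N2CC[C@H]3CN[C@H]3C2)c1` differs from compound 1 by cyano in place of hydrogen on an aromatic carbon. For the measured compounds named here, the one measured step, a 1.7-fold lower number from compound 1 to compound 2 (0.22 log units; within the scatter), concerns a different substituent at a different place on the same ring and stays within the scatter, so no step beyond the scatter is expected in this assay. Compound 3 is therefore expected at 40 nM, between 12 nM and 130 nM. The expected step is a 1.2-fold lower number from compound 1 to compound 3 (0.08 log units; within the scatter).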

Compound 3, half-maximal effective concentration: 1000 nM
For compound 3 the middle estimate is 25-fold (1.40 log units) below the measured one; the measured number lies above the stated range.
By their numbers in this assay, from the lowest: compounds 2 and 1 (each within the scatter of the next); then compound 3.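

In this assay, cyano in place of hydrogen on an aromatic carbon, two atoms from the ring nitrogen, gives a large loss (a 21-fold higher number from compound 1 to compound 3 (1.32 log units; beyond the scatter)). The core of compound 1 therefore does not accept every substituent on this ring, although the chloro change stayed within the scatter (a 1.7-fold lower number from compound 1 to compound 2 (0.22 log units; within the scatter)). Nothing given here explains the large step. The compounds shown leave open whether the loss follows the nitrile itself or this position, since chloro sits elsewhere on the ring. From the compounds shown here alone, how chloro, an amine or a methoxy group would behave at this same carbon also remains open.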